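Adding a Second Chlorine to Compound 3

This account rests on a few compounds, and the source may have more. Where it says the series, first, only, none or still open, it means among the compounds named here.

Compound 1, `O=C(Nc1ccc(Cl)cc1)c1cn(-c2ccccc2)nc1-c1ccccc1`, gives 3520 nM.
Compound 2, `Cc1ccc(-c2nn(-c3ccccc3)cc2C(=O)Nc2ccccc2)cc1`, gives 2360 nM.
Compound 3, `O=C(Nc1ccccc1)c1cn(-c2ccccc2)nc1-c1ccc(Cl)cc1`, gives 2180 nM.

All three were tested in a functional assay on HCT-116 cells (Homo sapiens) for cytotoxicity, read by MTT assay, with a stated time of 48 h; on this read-out higher numbers stand for weaker inhibition and lower numbers for stronger inhibition. The three numbers sit close together: compound 3 lies within the usual scatter of both compound 2 and compound 1, so the measurements do not separate any of them.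

Compound 4, `O=C(Nc1ccc(Cl)cc1)c1cn(-c2ccccc2)nc1-c1ccc(Cl)cc1`, differs from compound 3 by chloro in place of hydrogen on an aromatic carbon. Among the measured compounds shown here, the only single-point step measured so far is a 1.1-fold lower number from compound 2 to compound 3 (0.03 log units; within the scatter), a swap of methyl for chloro on the other ring, and it stayed within the scatter. For the measured compounds named here, no measured step adds a chloro at the place where it enters in compound 4. Compound 1 carries that chloro, but it differs from compound 3 in two places, and its value and that of compound 3 lie within scatter of each other. On this evidence the expected step in this assay is small, with no clear direction: a 1.1-fold higher number from compound 3 to compound 4 (0.06 log units; within the scatter) is what is expected. Compound 4 is therefore estimated at 2500 nM, with a likely range from 1000 nM to 6500 nM.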

Compound 4, half-maximal inhibitory concentration: 2990 nM
The estimate for compound 4 lay 1.2-fold (0.08 log units) below the measured number; measured number inside the range.
By their numbers in this assay, from the lowest: compounds 3, 2, 4 and 1 (each within the scatter of the next).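

In this assay the chloro on the amide side can now be read on its own: going from anilino to (4-chlorophenyl)amino gives a 1.4-fold higher number from compound 3 to compound 4 (0.14 log units; within the scatter) in a pair that differs in that one place. The same exchange of hydrogen for chloro on the other ring, from phenyl to 4-chlorophenyl, gives a 1.2-fold lower number from compound 1 to compound 4 (0.07 log units; within the scatter) so at both places a second chloro leaves the number within the scatter of the compound with one chloro. No supporting measurement bears on why these steps are so small.

Still open, from the compounds shown here alone, is whether a different group at these places, such as an amine, a carboxylic acid or a longer chain, would move the number beyond the scatter. Also open, going by these compounds, is what a change on the remaining phenyl ring, the same in all four compounds, would do.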